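Urea nitrogen substituent series on a shared quinolinyl-oxadiazole core

This account rests on a few compounds, and the source may have more. Where it says the series, first, only, none or still open, it means among the compounds named here.

Measured compounds:
compound 1, `O=C(Nc1ccccc1Cl)N1CCN(c2nc(-c3ccc4ccccc4n3)no2)CC1`, 140 nM;
compound 2, `C[C@@H]1C[C@H](c2nc(-c3ccc4ccccc4n3)no2)CCN1C(=O)Nc1ccccc1Cl`, 2400 nM;
compound 3, `Cc1noc(C)c1NC(=O)N1CCC(c2nc(-c3ccc4ccccc4n3)no2)CC1`, 3000 nM.

In a functional assay on Shh Light II cells (Mus musculus) for inhibition, read by a luciferase reporter (on this read-out higher numbers stand for weaker inhibition and lower numbers for stronger inhibition), compound 3 gives 3000 nM, the highest number of the three measured. Its nearest neighbour is compound 2, whose number lies within the scatter of that of compound 3, so no order between these two can be read. Compound 1 lies well below both, beyond the scatter. Within the data shown here, the three measured compounds differ from one another in more than one place, so no single step between them can be isolated.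

Compound 4, `O=C(NC1CCNCC1)N1CCC(c2nc(-c3ccc4ccccc4n3)no2)CC1`, is the next compound for this assay. It differs from compound 3 in one place: piperidin-4-yl in place of 3,5-dimethyl-1,2-oxazol-4-yl on an amide-type nitrogen. Nothing among the measured compounds shows a change of this kind on the amide-type nitrogen, so the direction of the step rests on no shown number. The step of a 2.0-fold lower number from compound 3 to compound 4 (0.30 log units; within the scatter) is expected to be small, possibly toward stronger inhibition but not clearly beyond the scatter. Compound 4 is expected to give 1500 nM, within a range from 400 nM to 6000 nM.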

Compound 4, half-maximal inhibitory concentration: 2500 nM
Compound 4: the middle estimate sits 1.7-fold (0.22 log units) below what was measured; the measured number falls inside the stated range.
By their numbers in this assay, from the lowest: compound 1; then compounds 2, 4 and 3 (each within the scatter of the next).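

In this assay, among these compounds, the step from 3,5-dimethyl-1,2-oxazol-4-yl to piperidin-4-yl on the amide-type nitrogen is a 1.2-fold lower number from compound 3 to compound 4 (0.08 log units; within the scatter), the first single-place comparison. At this position, an aromatic five-membered ring and a non-aromatic six-membered ring therefore cannot be told apart by this read-out, even though the entering group also brings a hydrogen-bond donor that the leaving group lacks. No measured property bears on this result, so it remains a bare observation.

As far as these compounds go, compound 1, at 140 nM, differs from compound 3 and compound 4 in more than one place, so the steps to it cannot be read and the source of its lower number stays open. From the compounds shown here alone, whether this position stays as insensitive to non-ring groups, such as a carboxylic acid or a longer alkyl chain on the amide-type nitrogen, also stays open.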